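Adding methoxy to the 4-hydroxyphenyl compound

The compounds below may be only part of what the source reports. "The series", "measured", "known", "first", "only" and "open" are said of these compounds alone.

For the measured compounds named here, in a functional assay on NRK-49F cells (Rattus norvegicus) for cytotoxicity, read by MTT assay, with a stated time of 24 h (on this read-out lower numbers stand for stronger inhibition and higher numbers for weaker inhibition), compound 1 `C/C(=N\NC(=O)/C(C#N)=C/c1ccccc1)c1c(O)c2ccc(O)cc2oc1=O` gives 55500 nM and compound 2 `C/C(=N\NC(=O)/C(C#N)=C/c1ccc(O)cc1)c1c(O)c2ccc(O)cc2oc1=O` gives 61300 nM, so compound 2 stands within the scatter of the only other measured number. Going by the values given here, the single measured step, a 1.1-fold higher number from compound 1 to compound 2 (0.04 log units; within the scatter), is hydroxy in place of hydrogen on an aromatic carbon.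

Compound 3 `COc1cc(/C=C(\C#N)C(=O)N/N=C(\C)c2c(O)c3ccc(O)cc3oc2=O)ccc1O` carries 4-hydroxy-3-methoxyphenyl where compound 2 has 4-hydroxyphenyl: methoxy in place of hydrogen on an aromatic carbon. This is methoxy in place of hydrogen on an aromatic carbon, ortho to a hydroxy group and meta to a large group.

Among the compounds with values here, no methoxy step has been measured, and the one step available on this ring is small, at a 1.1-fold higher number from compound 1 to compound 2 (0.04 log units; within the scatter). In this assay no change beyond the scatter is therefore expected, and the estimated step is a 1.0-fold lower number from compound 2 to compound 3 (0.01 log units; within the scatter). For compound 3 the expected value is 60000 nM, with an estimated range of 30000 nM to 120000 nM.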

Compound 3, half-maximal inhibitory concentration: 55400 nM
For compound 3 the middle estimate is 1.1-fold (0.03 log units) above the measured one; the range from low to high includes it.
By their numbers in this assay, from the lowest: compounds 3, 1 and 2 (each within the scatter of the next).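

In this assay, for the compounds shown here, methoxy in place of hydrogen on an aromatic carbon, ortho to a hydroxy group and meta to a large group, gives a first reading for this position (a 1.1-fold lower number from compound 2 to compound 3 (0.04 log units; within the scatter)), and the position takes methoxy with no change beyond the scatter. Going from phenyl to 4-hydroxy-3-methoxyphenyl (a 1.0-fold lower number from compound 1 to compound 3 (0.00 log units; within the scatter)) also stays within the scatter, so hydroxy and methoxy on this ring together leave the number where it was. Nothing available on these compounds accounts for this flat result.

Open, on these data alone, is whether any group at this position moves the number beyond the scatter, for example an amine, a carboxylic acid or a longer alkoxy chain in place of methoxy. Also open, as far as these compounds go, is whether methoxy gives the same small step on a ring without the hydroxy group.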